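A few compounds are considered here, and "the series" means these few. Any claim that something is new, unique, unknown or untested is made for them only; others in the source may bear on it.

Measured in a functional assay on HepG2 cells (Homo sapiens) for cytotoxicity, read by luminescence, with a stated time of 72 h; on this read-out higher numbers stand for an effect only at larger amounts of compound and lower numbers for an effect already at smaller amounts:
- Compound 1 `CN(Cc1cccc(F)c1)C(=O)c1cnc(-c2ccc(S(C)(=O)=O)c([N+](=O)[O-])c2)s1`: > 27000 nM (a limit)
- Compound 2 `CC1(C)CC2CC(C)(CN2C(=O)c2sc(-c3ccc(S(C)(=O)=O)c([N+](=O)[O-])c3)nc2C(F)(F)F)C1`: > 27000 nM (a limit)

Compound 2 gives > 27000 nM, which is a limit of the assay and not a number. The same holds for compound 1, so the data so far amount to the limit of > 27000 nM in this assay, at which 2 of the 2 values shown sit. Among the measured compounds shown here, no measured step is available to show how much a structural change can move this read-out.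

Compound 3 `CN(Cc1cccc(F)c1)C(=O)c1sc(-c2ccc(S(C)(=O)=O)c([N+](=O)[O-])c2)nc1C(F)(F)F` differs from compound 2 at a single place, on a carbonyl carbon: a group of 10 heavy atoms (8 carbon, 1 nitrogen, 1 fluorine; one six-membered aromatic ring of carbon only) in place of a group of 11 heavy atoms (10 carbon, 1 nitrogen; one five-membered non-aromatic ring with 1 hetero atom, one six-membered non-aromatic ring of carbon only), on a carbonyl carbon. The (3-fluorobenzyl)(methyl)amino group enters there.

The expectation rests on compound 2, whose > 27000 nM is a limit. No shift beyond the usual scatter, in either direction, is expected in this assay. The expected change is a number no higher from compound 2 to compound 3 (the limit leaves the size open). The estimated value for compound 3 is 27000 nM, with an expected range of 13000 nM to 54000 nM.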

Compound 3, half-maximal effective concentration: > 27000 nM
Compound 3: only a limit was reported; the forecaster's own chance of this, stated with the estimate: 85%; the middle value sits exactly at the limit.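

Compound 3 gives > 27000 nM, which is a limit of the assay and not a number. The steps to it from compound 1 and from compound 2 therefore cannot be read. The compounds shown leave open whether any structural change would bring this read-out to an actual number.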